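Swapping a Ring on a Piperidine: Stability Outlook

The compounds below may be only part of what the source reports. "The series", "measured", "known", "first", "only" and "open" are said of these compounds alone.

Among the compounds with values here, compound 1, `Cc1nc(N2CCC(N3CCCS3(=O)=O)CC2)nc2ccc(NC(=O)/C=C/c3ccc(OC(F)(F)F)cc3)cc12`, is the only member of this small set with a number behind it. In an ADME assay on microsomes from liver (Homo sapiens) for metabolic stability, with a stated time of 30 min (on this read-out lower numbers stand for a less stable compound and higher numbers for a more stable compound), compound 1 gives 85%, which places it firmly on the stable end of the read-out; with no other number to compare against, it stands alone. Two related compounds, compound 2, `Cc1nc(NCCNC(=O)C2CC2)nc2ccc(NC(=O)/C=C/c3ccc(OC(F)(F)F)cc3)cc12`, and compound 3, `C/C(=C\C(=O)Nc1ccc2nc(N3CCC(N4CCCC4=O)CC3)nc(C)c2c1)c1ccc(OC(F)(F)F)cc1`, were carried into the same study, but in this assay compound 2 gives "not determined" (no result reported) and compound 3 gives "not determined" (no result reported), so they offer no comparison.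

Compound 4, `Cc1nc(N2CCC(N3CCN(C)C3=O)CC2)nc2ccc(NC(=O)/C=C/c3ccc(OC(F)(F)F)cc3)cc12`, differs from compound 1 in a single place: a group of 7 heavy atoms (4 carbon, 2 nitrogen, 1 oxygen; one five-membered non-aromatic ring with 2 hetero atoms) in place of a group of 7 heavy atoms (3 carbon, 1 nitrogen, 2 oxygen, 1 sulfur; one five-membered non-aromatic ring with 2 hetero atoms), on a saturated ring carbon. Within the data shown here, no step between two measured compounds is available to calibrate how such a change plays out, so the expectation rests on compound 1 alone. Because compound 1 already sits near the top of the scale with 85%, there is little room upward, and a modest downward drift seems the more likely outcome, although it may stay inside the scatter. The expected step from compound 1 to compound 4 is a number 10 percentage points lower from compound 1 to compound 4 (within the scatter). Compound 4 is therefore estimated at 75%, within a range from 55% to 92%.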

Compound 4, percent of the compound remaining: 33%
Beside the measured number, compound 4's estimate is 42 percentage points above it, outside the stated range (below it).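

This step shows that the position, a saturated ring carbon three ring bonds from the ring nitrogen, does not tolerate every five-membered ring equally: in this assay the exchange gives a number 52 percentage points lower from compound 1 to compound 4 (beyond the scatter). The leaving group and 3-methyl-2-oxoimidazolidin-1-yl both have 7 heavy atoms and one five-membered non-aromatic ring with 2 hetero atoms, so these shared counts do not secure the stability seen for compound 1. The data shown offer no measured explanation for the step.

It remains open whether the methyl group on the entering ring plays any part in this step, since no partner lacking only that methyl group is shown. Going by these compounds, how an amine, a carboxylic acid or a longer chain at this same position would behave also remains open.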